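The source may report more compounds than this note shows. Statements on the series, on what has been measured and on what is new or still open speak of the compounds shown alone.

Compound 1 `CC1=C(C(=O)SC(C)C)C(c2ccsc2)NC(=O)N1` in an assay on membranes from HeLa cells for displacement of a labelled ligand from adenosine receptor A3 (Homo sapiens), read by scintillation counting, with a stated time of 180 min, tested at 1 uM; on this read-out lower numbers stand for less inhibition and higher numbers for more inhibition at the one concentration tested (going by the name of the read-out): 1%
Compound 2 `CCC(CC)OC(=O)C1=C(C)NC(=O)NC1c1ccsc1` in this assay: 6%

Compound 2 gives the larger of the two numbers shown, but the gap from compound 1, a number 5 percentage points higher from compound 1 to compound 2 (within the scatter), lies within the scatter. Compound 3 `CC1=C(C(=O)OC2CCCC2)C(c2ccsc2)NC(=O)N1` differs from compound 2 by cyclopentyl in place of pentan-3-yl on an oxygen next to a carbonyl group, the exchange sitting on an oxygen next to a carbonyl group. Among the compounds with values here, the one measured step also reworked the group on the carbonyl carbon and stayed within the scatter, so a further alkyl swap at the same place is expected to give no step beyond the scatter, a number 1 percentage points lower from compound 2 to compound 3 (within the scatter). Compound 3 is expected at 5%, range -5% to 15%.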

Compound 3, a percentage reported as inhibition, at one concentration (the size of the read-out at that concentration, not a potency): 5%
The estimate for compound 3 equals the measured number at the digits printed; measured number inside the range.
By their numbers in this assay, from the lowest: compounds 1, 3 and 2 (each within the scatter of the next).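

In this assay the exchange of pentan-3-yl for cyclopentyl on an oxygen next to a carbonyl group gives a number 1 percentage points lower from compound 2 to compound 3 (within the scatter) and so adds a ring without a step beyond the scatter. Cyclopentyloxy in place of isopropylsulfanyl on a carbonyl carbon gives a number 4 percentage points higher from compound 1 to compound 3 (within the scatter) and the three groups at this place cannot be told apart at the one concentration tested. No evidence on a cause bears on these steps.

Still open, as far as these compounds go, is whether any group at this place gives a step beyond the scatter, for instance an amine or a carboxylic acid in place of the alkyl group on the oxygen. Also open, from the compounds shown here alone, is how a change elsewhere on the shared core would read.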